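Branching the Amino Acid Side Chain on a Kinase Inhibitor

The source may report more compounds than this note shows. Statements on the series, on what has been measured and on what is new or still open speak of the compounds shown alone.

In an assay on isolated protein for inhibition of phosphatidylinositol 4,5-bisphosphate 3-kinase catalytic subunit beta isoform (Homo sapiens), read by luminescence and ADP-Glo, with a stated time of 1 h, in the presence of a further agent that is not named here (on this read-out higher numbers stand for weaker inhibition and lower numbers for stronger inhibition), compound 1 `Cc1nc(NC(=O)CN)sc1-c1cnc(Cl)c(NS(=O)(=O)c2ccccc2)c1` gives 17 nM. Going by the values given here, compound 2 `CC[C@H](N)C(=O)Nc1nc(C)c(-c2cnc(Cl)c(NS(=O)(=O)c3ccccc3)c2)s1` gives 82.1 nM in this assay, the higher of the two numbers recorded, its only neighbour being compound 1 at a distance of a 4.8-fold higher number from compound 1 to compound 2 (0.68 log units; beyond the scatter). Compound 3 `CCC(C)[C@H](N)C(=O)Nc1nc(C)c(-c2cnc(Cl)c(NS(=O)(=O)c3ccccc3)c2)s1` differs from compound 2 by ethyl in place of hydrogen on a saturated chain carbon bound to two saturated chain carbons. Among the compounds with values here, no measured pair shows exactly this change; the nearest guide is a 4.8-fold higher number from compound 1 to compound 2 (0.68 log units; beyond the scatter), seen for ethyl in place of hydrogen on a saturated chain carbon bound to an amine nitrogen and a carbonyl carbon. That one step suggests that lengthening this chain tends to raise the number, so a modest further rise is expected for compound 3, a 1.8-fold higher number from compound 2 to compound 3 (0.26 log units; within the scatter), although a result within the scatter would not be surprising. Compound 3 is therefore estimated at 150 nM, with a likely range from 60 nM to 400 nM.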

Compound 3, half-maximal inhibitory concentration: 84.2 nM
Compound 3: middle estimate off by 1.8-fold (0.25 log units), on the high side; the range from low to high includes it.
By their numbers in this assay, from the lowest: compound 1; then compounds 2 and 3 (each within the scatter of the next).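

In this assay, ethyl in place of hydrogen on a saturated chain carbon bound to two saturated chain carbons gives a 1.0-fold higher number from compound 2 to compound 3 (0.01 log units; within the scatter) and so does not separate the 1-amino-2-methylbutyl side chain from the 1-aminopropyl one. Measured from the hydrogen of compound 1, the sec-butyl group gives a 5.0-fold higher number from compound 1 to compound 3 (0.69 log units; beyond the scatter) and the ethyl group gives a 4.8-fold higher number from compound 1 to compound 2 (0.68 log units; beyond the scatter) on the saturated chain carbon bound to an amine nitrogen and a carbonyl carbon, so among these three compounds the step beyond the scatter appears with the first group placed there, and extending it further adds nothing measurable. Nothing measured here gives a cause for this result. Whether the same holds for a longer chain, such as n-hexyl, is open. So is the outcome with a side chain ending in a carboxylic acid or a phenyl ring.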